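Adding a Nitro Group to the Central Ring

The source may hold more compounds than are shown below. What is called first, only, known or untested is meant among the compounds shown, and "the series" means these compounds.

Measured so far:
- compound 1, `O=[N+]([O-])c1cc(-c2nc3ccc([N+](=O)[O-])cc3[nH]2)cc(-c2nc3ccc([N+](=O)[O-])cc3[nH]2)c1`, gives 1200 nM in a functional assay on MCF7 cells (Homo sapiens) for cytotoxicity, read by MTT assay, with a stated time of 48 h; a lower number here means a stronger inhibitor, a higher number a weaker inhibitor
- compound 2, `FC(F)(F)c1ccc2nc(-c3cccc(-c4nc5ccc(C(F)(F)F)cc5[nH]4)c3)[nH]c2c1`, gives 12800 nM in this assay

Of the two measured compounds, compound 2 gives the higher number, so it is the weaker inhibitor; its gap to compound 1 lies beyond the usual scatter. Compound 3, `O=[N+]([O-])c1cc(-c2nc3ccc(C(F)(F)F)cc3[nH]2)cc(-c2nc3ccc(C(F)(F)F)cc3[nH]2)c1`, is not yet measured. It differs from compound 2 in one place: nitro in place of hydrogen on an aromatic carbon, meta to two large groups. Within the data shown here, no measured pair shows this change on its own, and compound 1 differs from compound 3 in other places as well, so no step between measured compounds tells its size. The expectation is a moderate step toward a lower number, a 2.6-fold lower number from compound 2 to compound 3 (0.41 log units; beyond the scatter), with wide uncertainty. Compound 3 is therefore estimated at 5000 nM, within a range from 1500 nM to 15000 nM.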

Compound 3, half-maximal inhibitory concentration: 9400 nM
Estimate against measurement, compound 3: 1.9-fold (0.27 log units) below, and the stated range covers the measured number.
By their numbers in this assay, from the lowest: compound 1; then compounds 3 and 2 (each within the scatter of the next).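

In this assay, among these compounds, the nitro group on an aromatic carbon of this six-membered ring, meta to two large groups, can now be read on its own for the first time: a 1.4-fold lower number from compound 2 to compound 3 (0.13 log units; within the scatter). At this position, then, swapping hydrogen for nitro does not separate the two compounds, since the step stays inside the normal spread of repeated measurements. Nothing measured here offers an explanation for this result.

The compounds shown leave open what an amine or a carboxylic acid would give at this same carbon, and whether either would move the number beyond that spread. Compound 1 does not settle how the nitro group behaves with other groups elsewhere on the molecule, as it differs from compound 3 in other places as well.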